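Compound 3 and the loss of its bromo group

This account rests on a few compounds, and the source may have more. Where it says the series, first, only, none or still open, it means among the compounds named here.

In a functional assay on HepG2 cells (Homo sapiens) for inhibition, read by MTT assay, with a stated time of 72 h (on this read-out higher numbers stand for weaker inhibition and lower numbers for stronger inhibition), compound 3 (`Brc1ccc(-c2nnc(SCCCN3CCN(c4nc5ccccc5s4)CC3)o2)cc1`) gives 103000 nM and stands level with the other two measured compounds. Compound 1 (`c1ccc(-c2nnc(SCCCN3CCN(c4nc5ccccc5o4)CC3)o2)cc1`) stands at 102000 nM and compound 2 (`Clc1ccc(-c2nnc(SCCCN3CCN(c4nc5ccccc5s4)CC3)o2)cc1`) at 87700 nM on the same scale, so all three lie within the scatter of each other. Compound 4 (`c1ccc(-c2nnc(SCCCN3CCN(c4nc5ccccc5s4)CC3)o2)cc1`) differs from compound 3 by a single change (hydrogen in place of bromo on an aromatic carbon): hydrogen in place of bromo on an aromatic carbon, para to a large group. Among the measured compounds shown here, the one measured step on that carbon exchanges chloro for bromo, and it amounts to a 1.2-fold higher number from compound 2 to compound 3 (0.07 log units; within the scatter) with no separation of the two compounds. For the measured compounds named here, no measured step removes a halogen outright. Compound 1 already carries a phenyl group on a different core, and its value (102000 nM) offers no sign of a shift. No step beyond the scatter is therefore expected in this assay, and the estimated step is a 1.1-fold lower number from compound 3 to compound 4 (0.04 log units; within the scatter) for this change. For compound 4 the expected value is 95000 nM (estimated range 50000 nM to 180000 nM).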

Compound 4, half-maximal inhibitory concentration: 217000 nM
Estimate against measurement, compound 4: 2.3-fold (0.36 log units) below; the measured number lies above the stated range.
By their numbers in this assay, from the lowest: compounds 2, 1 and 3 (each within the scatter of the next); then compound 4.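

In this assay this carbon proves sensitive to the loss of its halogen: hydrogen in place of bromo gives a 2.1-fold higher number from compound 3 to compound 4 (0.32 log units; beyond the scatter) and hydrogen in place of chloro gives a 2.5-fold higher number from compound 2 to compound 4 (0.39 log units; beyond the scatter) as a step of the same modest kind. The exchange of one halogen for the other had shown nothing of this, since it gives only a 1.2-fold higher number from compound 2 to compound 3 (0.07 log units; within the scatter) and leaves the two compounds unseparated. With the phenyl group left bare, the other end of the molecule also registers, as 1,3-benzothiazol-2-yl in place of 1,3-benzoxazol-2-yl gives a 2.1-fold higher number from compound 1 to compound 4 (0.33 log units; beyond the scatter) and so sets the two apart.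

Going by these compounds, whether a methoxy group, an amine or a carboxylic acid on this carbon would hold the stronger side, and whether a halogen would act alike with the 1,3-benzoxazol-2-yl group in place, stays open. Nothing at hand accounts for these steps.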